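The compounds below may be only part of what the source reports. "The series", "measured", "known", "first", "only" and "open" are said of these compounds alone.

Series notes. In an assay on isolated protein for binding affinity to melanin-concentrating hormone receptor 1 (Homo sapiens) (on this read-out higher numbers stand for weaker inhibition and lower numbers for stronger inhibition), compound 1 `COc1cc(OC)cc(C(=O)NC2CCN(Cc3ccc4ccccc4c3)CC2)c1` gives 27 nM, and compound 2 `O=C(NCc1ccc(F)c(F)c1)[C@H]1[C@@H]2CN(Cc3ccc4ccccc4c3)C[C@@H]21` gives 40 nM; compound 2 holds the higher of the two numbers, yet its gap to compound 1 stays within the scatter, so neither is set apart. Compound 3 `O=C(NCc1ccc(F)c(F)c1)[C@@H]1[C@@H]2CN(Cc3ccc4ccccc4c3)C[C@@H]21` differs from compound 2 as follows: the two compounds have the same atoms and bonds and differ only in configuration as drawn: 1 of 3 stereo elements differ; a stereocentre at a saturated ring carbon is drawn r in compound 2 and s in compound 3. For the measured compounds named here, no measured pair in this set shows what such a change of configuration does here, so only a broad expectation is possible. In this assay the expected step is a 2.8-fold higher number from compound 2 to compound 3 (0.44 log units; beyond the scatter), toward weaker inhibition and probably beyond the scatter. Compound 3 is therefore estimated at 110 nM, within 30 nM to 450 nM.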

Compound 3, inhibition constant: > 100000 nM
Compound 3: only a limit was reported; the forecaster's own chance of this, stated with the estimate: 3%; middle value at least 900-fold (2.95 log units) from the limit.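

In this assay, for the compounds shown here, the configuration at this one saturated ring carbon carries the whole result, which the earlier compounds could not show: the fact that compounds 2 and 3 differ only in the configuration as drawn. Going by these compounds alone, changing this stereocentre from r to s gives an at least 2500-fold higher number from compound 2 to compound 3 (3.39 log units; beyond the scatter), the only such change with a read-out in this set. Compound 3 is reported only as a limit, > 100000 nM, so the step has no upper end.

Open, from the compounds shown here alone, is whether the r configuration stays as decisive when the fluorinated benzyl group on the amide gives way to a pyridylmethyl group or a longer alkyl chain. Going by these compounds, what the other two stereo elements contribute also stays open.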